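Cytotoxicity notes: aryloxy to cyanobenzyl on the quinoline-type core

The compounds below may be only part of what the source reports. "The series", "measured", "known", "first", "only" and "open" are said of these compounds alone.

Measured compounds:
compound 1 `COc1cccc(Oc2ccc3c(NCCCNCc4cc(F)ccc4OC)ccnc3c2)c1`, 7100 nM
compound 2 `Fc1ccc(Cc2ccc3c(NCCCNCc4ccco4)ccnc3c2)c(Cl)c1`, 5730 nM
compound 3 `COc1cccc(Oc2ccc3c(NCCCNCc4cccc(OC)c4O)ccnc3c2)c1`, 5300 nM

All three were run in an ADME assay on HepG2 cells (Homo sapiens) for cytotoxicity, read by luminescence, CellTiter-Glo and ATP content, with a stated time of 72 h; a higher number here means that more compound is needed for the effect, a lower number that less compound is needed. Compound 1 gives the highest of the three numbers, but its gap to compound 2 and to compound 3 sits within the scatter, so no order among them can be claimed. Among the measured compounds shown here, the only single-site step is a 1.3-fold lower number from compound 1 to compound 3 (0.13 log units; within the scatter), a change on the saturated chain carbon bound to the amine nitrogen, far from the place altered here.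

Compound 4 `COc1ccc(F)cc1CNCCCNc1ccnc2cc(Cc3ccc(C#N)cc3)ccc12` is not yet measured. It differs from compound 1 as follows: 4-cyanobenzyl in place of 3-methoxyphenoxy on an aromatic carbon. For the measured compounds named here, no measured pair isolates this change. Compound 2 differs from compound 1 at more than one place, so only its value can be set beside that of compound 1; the two lie within the scatter of each other. The step 1 to 3 does not bear on the aryl replacement at the core.

With no step beyond the scatter anywhere in the set, the expectation for compound 4 is that the move from compound 1 stays within scatter: a 1.2-fold lower number from compound 1 to compound 4 (0.07 log units; within the scatter). Compound 4 is therefore estimated at 6000 nM, with a range of 2500 nM to 14000 nM.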

Compound 4, half-maximal effective concentration: 6050 nM
Beside the measured number, compound 4's estimate is 1.0-fold (0.00 log units) below it; the range from low to high includes it.
By their numbers in this assay, from the lowest: compounds 3, 2, 4 and 1 (each within the scatter of the next).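

Among the compounds shown here, the step at this position, on an aromatic carbon of the shared core, is the first single-site reading of the aryl replacement: in this assay it gives a 1.2-fold lower number from compound 1 to compound 4 (0.07 log units; within the scatter) and stays inside the scatter. With the 5-fluoro-2-methoxyphenyl end held constant, 3-methoxyphenoxy and 4-cyanobenzyl, each of 9 heavy atoms and each with one six-membered aromatic ring of carbon only, therefore cannot be told apart in this read-out, even though the ether link and methoxy give way to a carbon link and a nitrile. Nothing available accounts for this flat result.

The linker and the ring substituent change together in this step, so a plain benzyl, a 4-methoxybenzyl or a 3-methoxyphenyl group joined directly to the core would be needed to read each on its own. As far as these compounds go, it also remains open whether the position tolerates groups of a different kind, such as a primary amine, a carboxylic acid or a morpholine ring, and whether 4-cyanobenzyl behaves the same with the 2-hydroxy-3-methoxyphenyl or furan end on the chain.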